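This account rests on a few compounds, and the source may have more. Where it says the series, first, only, none or still open, it means among the compounds named here.

Measured so far:
compound 1 `Cc1nc(SCC(=O)Nc2nc(-c3ccc(Cl)cc3)cs2)n(Nc2ccccc2)c1C`, 4270 nM
compound 2 `Cc1ccc(Nn2c(SCC(=O)Nc3nc(-c4ccccc4)cs3)nc(C)c2C)cc1`, 35200 nM

In a functional assay on SF-539 cells (Homo sapiens) for antiproliferative activity, read by sulforhodamine B assay, with a stated time of 48 h (a lower number here means a stronger inhibitor of growth, a higher number a weaker inhibitor of growth), compound 1 gives 4270 nM, the lowest of the two numbers; compound 2 gives 35200 nM, a higher number, and the two lie beyond the scatter. For the measured compounds named here, compound 2 differs from compound 1 in more than one place, so no single step between them is available.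

Compound 3 `COc1ccc(Nn2c(SCC(=O)Nc3nc(-c4ccc(Cl)cc4)cs3)nc(C)c2C)cc1` differs from compound 1 in one place: methoxy in place of hydrogen on an aromatic carbon. Going by the values given here, no measured pair shows this change. A modest weakening is expected, the step of a 1.9-fold higher number from compound 1 to compound 3 (0.27 log units; within the scatter) in this assay, but it could also stay within the scatter. Compound 3 is expected to give 8000 nM, within 2500 nM to 25000 nM.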

Compound 3, concentration for total growth inhibition: > 100000 nM
Compound 3 ended at the assay's limit; the forecaster's own chance of this, stated with the estimate: 10%; at least 12-fold (1.09 log units) between middle value and limit.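

In this assay, the aromatic carbon para to a large group proves sensitive to substitution: methoxy in place of hydrogen gives an at least 23-fold higher number from compound 1 to compound 3 (1.36 log units; beyond the scatter). For the compounds shown here, this is the first single-place step. Its size is a bound and not a measured size, because compound 3 sits at a limit of the assay: the limit of > 100000 nM in this assay, at which 1 of the 3 values shown sits.

From the compounds shown here alone, whether any group at this carbon costs activity or methoxy alone does remains open; a fluorine, a hydroxyl or an amine there would help separate the two. Compound 2 carries methyl on this ring but also differs in another place, which leaves the question unsettled.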